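The source may hold more compounds than are shown below. What is called first, only, known or untested is meant among the compounds shown, and "the series" means these compounds.

Going by the values given here, compound 2 `CC(CC(=O)/N=C(\N)NCCCc1ccncc1)c1ccccc1` is one of two compounds measured in a functional assay on Sf9 cells for antagonist activity at histamine H2 receptor (Homo sapiens), with stated times of 2 min and 20 min (on this read-out lower numbers stand for lower potency and higher numbers for higher potency (the scale is a negative logarithm)), where compound 2 gives 5.54. Compound 1 `N/C(=N\C(=O)CC(c1ccccc1)c1ccccc1)NCCCc1ccccn1` gives 5.68 in this assay, a number within the scatter of compound 2. Compound 3 `N/C(=N\C(=O)CC(c1ccccc1)c1ccccc1)NCCCc1ccncc1` has not been measured in this assay. It differs from compound 2 by phenyl in place of methyl on a saturated chain carbon bound to an aromatic carbon and a saturated chain carbon. Among the compounds with values here, no comparable step between measured compounds is available, so compound 3 is expected to move little, with an estimated step of a number 0.16 log units higher from compound 2 to compound 3 (within the scatter) that is not expected to exceed the scatter. Compound 3 is therefore estimated at 5.7, in a range from 5.3 to 6.1.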

Compound 3, negative logarithm of the antagonist equilibrium constant: 6.14
Estimate against measurement, compound 3: 0.44 log units below, and the stated range ends below it.
By their numbers in this assay, from the lowest: compounds 2 and 1 (each within the scatter of the next); then compound 3.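

In this assay, phenyl in place of methyl on a saturated chain carbon bound to an aromatic carbon and a saturated chain carbon gives a number 0.60 log units higher from compound 2 to compound 3 (beyond the scatter), so this position responds to the change beyond the scatter. Pyridin-4-yl in place of pyridin-2-yl gives a number 0.46 log units higher from compound 1 to compound 3 (beyond the scatter), so the second phenyl and the pyridine form both count in this series. Nothing measured here accounts for either step. As far as these compounds go, whether a cyclohexyl group at that chain carbon would serve as phenyl does remains open, as do pyridin-3-yl and a longer chain.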